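Replacing Trifluoromethyl with Phenyl on a Sulfonyl Sulfur

The source may report more compounds than this note shows. Statements on the series, on what has been measured and on what is new or still open speak of the compounds shown alone.

Compound 1 `C[n+]1ccn(CCNS(=O)(=O)C(F)(F)F)c1/C=N/O` gives -1.2 in a physicochemical assay for lipophilicity; on this read-out higher numbers stand for higher lipophilicity and lower numbers for lower lipophilicity.
Compound 2 `CCN(CCn1cc[n+](C)c1/C=N/O)S(=O)(=O)C(F)(F)F` gives -1.03 in this assay.
Compound 3 `CCCN(CCn1cc[n+](C)c1/C=N/O)S(=O)(=O)C(F)(F)F` gives -0.69 in this assay.

Compound 2 holds the second highest of the three numbers in this assay. Its nearest neighbour is compound 1, as a number 0.17 log units higher from compound 1 to compound 2 (within the scatter) shows, and its furthest is compound 3, as a number 0.34 log units higher from compound 2 to compound 3 (beyond the scatter) shows. Compound 4 `CCN(CCn1cc[n+](C)c1/C=N/O)S(=O)(=O)c1ccccc1` differs from compound 2 in one place: phenyl in place of trifluoromethyl on a sulfonyl sulfur.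

Going by the values given here, no measured step touches the group on the sulfonyl sulfur. The steps that exist add carbon on or near the sulfonamide nitrogen, namely a number 0.51 log units higher from compound 1 to compound 3 (beyond the scatter) and a number 0.34 log units higher from compound 2 to compound 3 (beyond the scatter), and each ran upward, while a number 0.17 log units higher from compound 1 to compound 2 (within the scatter) stayed within the scatter. The change to compound 4 brings in more heavy atoms than any of those steps, so a modest rise beyond the scatter in this assay is expected, of the size a number 0.63 log units higher from compound 2 to compound 4 (beyond the scatter), because a number 0.51 log units higher from compound 1 to compound 3 (beyond the scatter) and a number 0.34 log units higher from compound 2 to compound 3 (beyond the scatter) both pointed that way. Compound 4 is therefore estimated at -0.4, with a range from -1 to 0.2.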

Compound 4, distribution coefficient: -1.39
Compound 4: middle estimate off by 0.99 log units, on the high side; the measured number lies below the stated range.
By their numbers in this assay, from the lowest: compounds 4, 1 and 2 (each within the scatter of the next, the first and the last beyond it); then compound 3.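

On the sulfonyl sulfur, the exchange of trifluoromethyl for phenyl runs opposite to the added carbon on the sulfonamide side chain: a number 0.36 log units lower from compound 2 to compound 4 (beyond the scatter) in this assay, whereas that chain gave a number 0.34 log units higher from compound 2 to compound 3 (beyond the scatter). Phenyl carries more heavy atoms than the trifluoromethyl it replaces and adds an aromatic ring, so among these compounds a larger group does not go with a higher number, and compound 4 is the exception to the upward steps. The group on the sulfonyl sulfur therefore cannot be read from the steps at the sulfonamide nitrogen.

Nothing in the available data accounts for this direction. With only two groups shown at this position, it remains open whether methyl or cyclohexyl on the sulfonyl sulfur would fall on the side of trifluoromethyl or of phenyl.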